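Swapping 3-nitrophenyl for 4-cyanophenyl on a shared core

The source may hold more compounds than are shown below. What is called first, only, known or untested is meant among the compounds shown, and "the series" means these compounds.

Of the compounds shown here, three with a shared core have been measured in a functional assay on K562 cells (Homo sapiens) for cytotoxicity, read by MTT assay, with a stated time of 24 h; a higher number here means a weaker inhibitor, a lower number a stronger inhibitor. Compound 1 `COc1cc(/C=C2\CN(C)C/C(=C\c3ccccc3F)C2=O)cc(OC)c1OC` gives 4340 nM, compound 2 `COc1cc(/C=C2\CN(C)C/C(=C\c3ccc(F)cc3)C2=O)cc(OC)c1OC` gives 10300 nM, and compound 3 `COc1cc(/C=C2\CN(C)C/C(=C\c3cccc([N+](=O)[O-])c3)C2=O)cc(OC)c1OC` gives 4200 nM. Two steps fix the place of the last of these: a 1.0-fold lower number from compound 1 to compound 3 (0.01 log units; within the scatter) and a 2.5-fold lower number from compound 2 to compound 3 (0.39 log units; beyond the scatter). It therefore stands level with one neighbour and clear of the other, on the low side.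

Compound 4 `COc1cc(/C=C2\CN(C)C/C(=C\c3ccc(C#N)cc3)C2=O)cc(OC)c1OC` differs from compound 3 on a double-bonded chain carbon bound to a double-bonded ring carbon: 4-cyanophenyl in place of 3-nitrophenyl on a double-bonded chain carbon bound to a double-bonded ring carbon. Among the measured compounds shown here, no measured step makes this exact swap, and no measured compound carries the 4-cyanophenyl group. The closest guide is the arrival of 4-fluorophenyl, which gave a 2.4-fold higher number from compound 1 to compound 2 (0.38 log units; beyond the scatter). For the measured compounds named here, a move toward a higher number in this assay, no larger than that step, is therefore expected. The estimated change is a 1.5-fold higher number from compound 3 to compound 4 (0.19 log units; within the scatter). For compound 4 the expected value is 6500 nM, with an estimated range of 3000 nM to 14000 nM.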

Compound 4, half-maximal inhibitory concentration: 4290 nM
For compound 4 the middle estimate is 1.5-fold (0.18 log units) above the measured one; low and high end bracket the measured number.
By their numbers in this assay, from the lowest: compounds 3, 4 and 1 (each within the scatter of the next); then compound 2.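

In this assay, 4-cyanophenyl at this place is level with both 3-nitrophenyl (a 1.0-fold higher number from compound 3 to compound 4 (0.01 log units; within the scatter)) and 2-fluorophenyl (a 1.0-fold lower number from compound 1 to compound 4 (0.01 log units; within the scatter)), so three different aryl groups now cannot be told apart here. Cyano in place of fluoro on an aromatic carbon separates compound 4 from compound 2 (a 2.4-fold lower number from compound 2 to compound 4 (0.38 log units; beyond the scatter)), the first comparison in which the group sits at the same ring number as in 4-fluorophenyl. The gap around compound 2 therefore does not follow that ring number alone, since compound 4 carries it and stays with compounds 1 and 3.

What sets the fluoro compound apart remains open, and nothing shown here bears on it. Also open, going by these compounds, is whether an amine or a carboxylic acid on this aryl ring would stay level with compounds 1, 3 and 4 or move away from them.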